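This account rests on a few compounds, and the source may have more. Where it says the series, first, only, none or still open, it means among the compounds named here.

In a functional assay on NCI-H460 cells (Homo sapiens) for cytotoxicity, read by MTT assay, with a stated time of 48 h (on this read-out higher numbers stand for weaker inhibition and lower numbers for stronger inhibition), compound 1 (`COc1ccc(/C=C/C(=O)/C=C/c2cc3ccccc3nc2Cl)cc1`) gives > 10000 nM, which is a limit. Compound 2 (`COc1ccc(/C=C/C(=O)/C=C/c2cc3ccccc3nc2Oc2ccccc2)cc1`) gives > 10000 nM, also a limit. Compound 3 (`COc1ccc(/C=C/C(=O)/C=C/c2cc3ccccc3nc2Oc2ccc(Br)cc2)cc1`) gives > 10000 nM, again a limit. The series therefore offers no number yet, only (the limit of > 10000 nM in this assay, at which 3 of the 3 values shown sit), and compound 3 stands there with the other two.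

Compound 4 (`COc1ccc(OC)c(/C=C/C(=O)/C=C/c2cc3ccccc3nc2Oc2ccc(Br)cc2)c1`) differs from compound 3 in one place, with 2,5-dimethoxyphenyl in place of 4-methoxyphenyl on a double-bonded chain carbon bound to a double-bonded chain carbon.

Three measured steps exist in the series: a step that the two limits leave unreadable from compound 1 to compound 2, a step that the two limits leave unreadable from compound 1 to compound 3 and a step that the two limits leave unreadable from compound 2 to compound 3. All three exchange chloro, phenoxy or bromo and leave the 4-methoxyphenyl untouched, and none has a readable size, so they give no size to carry over to this change. Starting from a limit, a readable result in this assay could only lie toward stronger inhibition, though a further limit remains quite possible.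

The expected change, loosely estimated, is an at least 2.5-fold lower number from compound 3 to compound 4 (0.39 log units; beyond the scatter), toward stronger inhibition. For compound 4 the estimated value is 4000 nM, with an expected range from 500 nM to 15000 nM.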

Compound 4, half-maximal inhibitory concentration: > 10000 nM
Compound 4: only a limit was reported; the forecaster's own chance of this, stated with the estimate: 45%; middle value at least 2.5-fold (0.39 log units) away from the limit.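

In this assay compound 4 gives > 10000 nM, which is a limit. Compound 3 also stands at a limit, so the change from compound 3 to compound 4 cannot be read and has no size. The compounds shown leave open what number any of them would reach, since all share one limit: the limit of > 10000 nM in this assay, at which 4 of the 4 values shown sit.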